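This account rests on a few compounds, and the source may have more. Where it says the series, first, only, none or still open, it means among the compounds named here.

Measured compounds in a functional assay on MCF7 cells (Homo sapiens) for antiproliferative activity, read by CCK-8 assay, with a stated time of 72 h; on this read-out higher numbers stand for weaker inhibition of growth and lower numbers for stronger inhibition of growth: compound 1 `CCC1C(=O)N(C)c2cnc(Nc3ccc(S(=O)(=O)NCC(C)C)cc3)nc2N1c1ccn(C)n1` gives 8350 nM; compound 2 `CCCNS(=O)(=O)c1ccc(Nc2ncc3c(n2)N(c2ccn(C)n2)C(CC)C(=O)N3C)cc1` gives 3000 nM; compound 3 `CCCNC(=O)c1ccc2c(ccn2-c2ncc3c(n2)N(C2CCCC2)[C@H](CC)C(=O)N3C)c1` gives 592 nM.

Compound 1 and compound 2 share a core and differ by one change, (methyl in place of hydrogen on a saturated chain carbon bound to two saturated chain carbons). That change made the step of a 2.8-fold higher number from compound 2 to compound 1 (0.44 log units; beyond the scatter). Compound 3 carries a different core; the difference between the two cores is not broken down here, and compound 3 gives the lowest number of the three measured compounds in this assay.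

Compound 4 `CCCCNC(=O)c1ccc2c(ccn2-c2ncc3c(n2)N(C2CCCC2)[C@H](CC)C(=O)N3C)c1` has not yet been measured. It differs from compound 3 by methyl in place of hydrogen on a saturated chain carbon, three bonds along the chain from an amide-type nitrogen. This is the same kind of change as that from compound 2 to compound 1, but the place is not the same: in compound 1 the methyl enters on a saturated chain carbon bound to two saturated chain carbons, whereas in compound 4 it enters on a saturated chain carbon three bonds along the chain from an amide-type nitrogen. Among the compounds with values here, the earlier step was a modest weakening, and a step of similar direction but smaller size is expected here, a 1.5-fold higher number from compound 3 to compound 4 (0.18 log units; within the scatter), because the only comparable step in hand is a 2.8-fold higher number from compound 2 to compound 1 (0.44 log units; beyond the scatter) and it occurred on a different core with a differently placed methyl. Compound 4 is therefore expected to give about 900 nM in this assay, with a likely range from 300 nM to 2500 nM.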

Compound 4, concentration for 50% growth inhibition: 634 nM
Beside the measured number, compound 4's estimate is 1.4-fold (0.15 log units) above it; the range from low to high includes it.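

In this assay, methyl in place of hydrogen on a saturated chain carbon, three bonds along the chain from an amide-type nitrogen, gave a 1.1-fold higher number from compound 3 to compound 4 (0.03 log units; within the scatter), so propyl to butyl on this core leaves the number within the scatter. Set beside the earlier step, this one cannot be told apart from it: the same change on two cores in this assay, a 2.8-fold higher number (0.44 log units; beyond the scatter) from compound 2 to compound 1 and a 1.1-fold higher number (0.03 log units; within the scatter) from compound 3 to compound 4, 2.6-fold (0.41 log units) apart, within the scatter of two such steps. Within the data shown here, this shows that the two cores need not be read as answering differently to this change, but it does not show that the change carries over unaltered; the comparison rests on only two pairs, with the methyl differently placed in each.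

The compounds shown leave open how the number would respond on the core of compound 3 to a longer chain, a branched chain, an amine or a carboxylic acid in place of the butyl chain. They also leave open how much of the gap between the two cores belongs to each of the places in which they differ.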